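Pyridin-4-yl replacing 1-methyl-1H-pyrazol-5-yl on the shared core

The source may report more compounds than this note shows. Statements on the series, on what has been measured and on what is new or still open speak of the compounds shown alone.

In a functional assay on VCaP cells (Homo sapiens) for antiproliferative activity, read by CCK-8 assay, with a stated time of 6 days (on this read-out higher numbers stand for weaker inhibition and lower numbers for stronger inhibition), compound 1 (`N#Cc1ccc(N2CCCc3c(-c4cccnc4)cccc32)cc1C(F)(F)F`) gives 13500 nM. Compound 2 (`Cn1nccc1-c1cccc2c1CCCN2c1ccc(C#N)c(C(F)(F)F)c1`) gives > 30000 nM, which is a limit of the assay and not a number. Compound 2 therefore stands at the top of the range shown: the limit of > 30000 nM in this assay, at which 1 of the 2 values shown sits.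

Compound 3 (`N#Cc1ccc(N2CCCc3c(-c4ccncc4)cccc32)cc1C(F)(F)F`) differs from it by pyridin-4-yl in place of 1-methyl-1H-pyrazol-5-yl on an aromatic carbon. For the measured compounds named here, the only measured step bearing on this swap is an at least 2.2-fold higher number from compound 1 to compound 2 (0.34 log units; beyond the scatter), with 1-methyl-1H-pyrazol-5-yl in place of pyridin-3-yl. The reverse direction is therefore expected here, towards lower numbers in this assay, of at least modest size: an at least 2.1-fold lower number from compound 2 to compound 3 (0.33 log units; beyond the scatter). Compound 3 is estimated at 14000 nM, with an expected range of 5000 nM to 30000 nM.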

Compound 3, half-maximal inhibitory concentration: > 30000 nM
Compound 3 ended at the assay's limit (the forecaster's own chance of this, stated with the estimate: 25%); at least 2.1-fold (0.33 log units) between middle value and limit.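

In this assay the step is an at least 2.2-fold higher number from compound 1 to compound 3 (0.34 log units; beyond the scatter) with pyridin-4-yl in place of pyridin-3-yl on this aromatic carbon, so a pyridine ring alone does not carry the read-out of compound 1. Compound 2 and compound 3 both end at a limit of the assay, and the step between them cannot be read. Only compound 1 stays short of that limit, which now holds most of the series: the limit of > 30000 nM in this assay, at which 2 of the 3 values shown sit.

Going by these compounds, whether an amine or a carboxylic acid on the pyridin-3-yl ring, or a plain phenyl ring on this aromatic carbon, would give lower numbers than compound 1 stays open.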